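A Longer Linker Beside a Fluoro Substituent

The compounds below may be only part of what the source reports. "The series", "measured", "known", "first", "only" and "open" are said of these compounds alone.

Measured so far:
compound 1, `CN(C)C(=O)c1cc2cnc(Nc3ccc(C(=O)NCCCCCN=C=S)cc3)nc2n1C1CCCC1`: 29.3%
compound 2, `CN(C)C(=O)c1cc2cnc(Nc3ccc(C(=O)NCCCCCCN=C=S)cc3)nc2n1C1CCCC1`: 35.8%
compound 3, `CN(C)C(=O)c1cc2cnc(Nc3ccc(C(=O)NCCCCCCN=C=S)cc3F)nc2n1C1CCCC1`: -11.8%

All three were tested in a functional assay on A549 cells (Homo sapiens) for inhibition, read by CCK-8 assay, with a stated time of 72 h, tested at 1 uM; a higher number here means a stronger effect of the compound at the concentration tested, a lower number a weaker effect. Compound 2 differs from compound 1 by a group of 4 heavy atoms (2 carbon, 1 nitrogen, 1 sulfur; no ring) in place of a group of 3 heavy atoms (1 carbon, 1 nitrogen, 1 sulfur; no ring), on a saturated chain carbon, five bonds along the chain from an amide-type nitrogen, and this step is a number 6.5 percentage points higher from compound 1 to compound 2 (within the scatter). Compound 3 differs from compound 2 by fluoro in place of hydrogen on an aromatic carbon, and that step is a number 47.6 percentage points lower from compound 2 to compound 3 (beyond the scatter), leaving compound 3 as the lowest of the three. The difference between the cores of compound 1 and compound 3 is not broken down here.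

Compound 4, `CN(C)C(=O)c1cc2cnc(Nc3ccc(C(=O)NCCCCCCCN=C=S)cc3F)nc2n1C1CCCC1`, has not yet been measured. It differs from compound 3 by a group of 4 heavy atoms (2 carbon, 1 nitrogen, 1 sulfur; no ring) in place of a group of 3 heavy atoms (1 carbon, 1 nitrogen, 1 sulfur; no ring), on a saturated chain carbon, six bonds along the chain from an amide-type nitrogen. This is the same kind of change as that from compound 1 to compound 2, but not the same: there it sat five bonds along the chain from an amide-type nitrogen, here six bonds along the chain. Since the earlier step was within the scatter, the step from compound 3 to compound 4 is expected to be small as well, estimated at a number 6.8 percentage points higher from compound 3 to compound 4 (within the scatter) because of a number 6.5 percentage points higher from compound 1 to compound 2 (within the scatter). Compound 4 is therefore expected to give about -5%, estimated to lie between -30% and 22%.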

Compound 4, a percentage reported as inhibition, at one concentration (the size of the read-out at that concentration, not a potency): 0.05%
Compound 4: middle estimate off by 5.1 percentage points, on the low side; the measured number falls inside the stated range.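

In this assay, the same kind of chain extension that was tried on the core of compound 1 was carried to the fluoro-bearing core and gave a number 11.9 percentage points higher from compound 3 to compound 4 (beyond the scatter), and the two steps do not differ beyond what repeated measurements would allow: the same change on two cores in this assay, a number 6.5 percentage points higher (within the scatter) from compound 1 to compound 2 and a number 11.9 percentage points higher (beyond the scatter) from compound 3 to compound 4, 5.4 percentage points apart, within the scatter of two such steps So, in these two pairs, the change carried over from one core to the other with a similar size, even though only the second step stands clear of the scatter on its own. For the compounds shown here, this does not show that the change would behave in the same way on other cores or at other chain lengths, as it rests on only two pairs, whose changes also sit at different places along the chain, and it gives no reason for the size of either step.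

Going by these compounds, what a longer chain would do on either core remains open. So does the effect of an amine or a carboxylic acid in place of the sulfur-bearing group on the chain.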